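A Shared Core, Three Aryl Groups, One Open Estimate

This account rests on a few compounds, and the source may have more. Where it says the series, first, only, none or still open, it means among the compounds named here.

Of the compounds shown here, three have been measured. Compound 1 `COc1ccc(-n2nncc2CN2C(=O)C3(C(C#N)=C(N)Oc4c3c3nc5ccccc5nc3c3ccccc43)c3ccccc32)cc1` in an ADME assay on L02 cells (Homo sapiens) for antiproliferative activity, read by MTT assay, with a stated time of 48 h (a higher number here means a weaker inhibitor, a lower number a stronger inhibitor), gives > 50000 nM, which is a limit of the assay and not a number. Compound 2 `N#CC1=C(N)Oc2c(c3nc4ccccc4nc3c3ccccc23)C12C(=O)N(Cc1cnnn1-c1ccc(Cl)c(Cl)c1)c1ccccc12` in this assay gives > 50000 nM, again a limit rather than a number. Between them lies the step that the two limits leave unreadable from compound 1 to compound 2, whose size cannot be read because both values sit at the limit of > 50000 nM in this assay, at which 2 of the 3 values shown sit. Among the compounds with values here, compound 3 `N#CC1=C(N)Oc2c(N)cc3nc4ccccc4nc3c2C12C(=O)N(Cc1cnnn1-c1ccccc1Br)c1ccccc12` in this assay gives 29200 nM, the only number among the three values shown. Compound 1 and compound 2 each sit at a limit of the assay, so compound 3 has no measured neighbour against which its standing can be placed.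

Compound 4 `Cc1cc(C)cc(-n2nncc2CN2C(=O)C3(C(C#N)=C(N)Oc4c(N)cc5nc6ccccc6nc5c43)c3ccccc32)c1` is not yet measured. It differs from compound 3 by 3,5-dimethylphenyl in place of 2-bromophenyl on an aromatic nitrogen. Within the data shown here, the one measured step that touches the same kind of change, from compound 1 to compound 2, left both values at the limit and so gives no readable size. With no readable step to lean on, the expectation for compound 4 in this assay is a step no larger than the usual scatter, in no fixed direction, with a real chance that only a limit is reported. Compound 4 is therefore estimated at 35000 nM, within 15000 nM to 80000 nM. That estimate corresponds to an expected step of a 1.2-fold higher number from compound 3 to compound 4 (0.08 log units; within the scatter).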

Compound 4, half-maximal inhibitory concentration: > 50000 nM
Compound 4: a limit, no number; the forecaster's own chance of this, stated with the estimate: 40%; at least 1.4-fold (0.15 log units) between middle value and limit.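

Placing 3,5-dimethylphenyl in place of 2-bromophenyl on an aromatic nitrogen of the five-membered aromatic ring gives the first step at this position that can be read at all in this assay: an at least 1.7-fold higher number from compound 3 to compound 4 (0.23 log units; that floor lies within the scatter). That size is only a floor, and since the floor lies within the scatter, the step does not by itself establish a real change at this position, although it does show that this change gives no lower number. Compound 3 now has a measured neighbour that differs from it in one place, yet it remains the only compound with a number, and the others offer no size to set beside it: the limit of > 50000 nM in this assay, at which 3 of the 4 values shown sit.

The compounds shown leave open how far the true step reaches, and whether the number of compound 3 depends on the bromine itself or would also appear with plain unsubstituted phenyl on this nitrogen. They also leave open whether a phenyl carrying a carboxylic acid or a primary amine at this position would give a number in this assay rather than a limit.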